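From Phenyl to tert-Butyl: One Untested Swap

The source may hold more compounds than are shown below. What is called first, only, known or untested is meant among the compounds shown, and "the series" means these compounds.

Compound 1 `O=C(NCc1cc(Cl)ccc1-n1cnnn1)[C@@H]1CC=NN1C(=O)[C@H](O)c1ccccc1`: 840 nM
Compound 2 `CC(C)(C)C[C@@H](O)C(=O)N1C[C@@H]2C[C@@H]2[C@H]1C(=O)NCc1cc(Cl)ccc1-n1cnnn1`: 910 nM

Both values come from a functional assay on a cell-free system (plasma, Homo sapiens), with a stated time of 3 min (on this read-out lower numbers stand for stronger inhibition and higher numbers for weaker inhibition), and lie within the usual scatter of each other. Compound 1 therefore holds no clear rank on these numbers, and the pair can only be described as alike in this read-out.

A further compound, compound 3 `CC(C)(C)[C@@H](O)C(=O)N1N=CC[C@H]1C(=O)NCc1cc(Cl)ccc1-n1cnnn1`, has not yet been measured. It keeps the core of compound 1 and changes a single group, with tert-butyl in place of phenyl on a saturated chain carbon bound to a carbonyl carbon and an oxygen on a saturated carbon. Among the compounds with values here, no measured pair of compounds shows this swap on its own, so any forecast is loose and the range must stay wide. Starting from compound 1 (840 nM), a moderate loss of inhibition in this assay seems the likeliest outcome, which would appear as a higher number. The expected change is a 2.4-fold higher number from compound 1 to compound 3 (0.38 log units; beyond the scatter) (an upward move). For compound 3 the expected value is 2000 nM (estimated range 500 nM to 6000 nM).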

Compound 3, half-maximal inhibitory concentration: 1400 nM
Estimate against measurement, compound 3: 1.4-fold (0.15 log units) above; low and high end bracket the measured number.
By their numbers in this assay, from the lowest: compounds 1, 2 and 3 (each within the scatter of the next).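

In this assay, placing tert-butyl in place of phenyl on a saturated chain carbon bound to a carbonyl carbon and an oxygen on a saturated carbon gives a 1.7-fold higher number from compound 1 to compound 3 (0.22 log units; within the scatter). Within the data shown here, this is the first comparison here in which only one place differs, and it shows that this position can hold either an aromatic ring of carbon or tert-butyl, which has no ring and fewer heavy atoms, without a difference that stands clear of the scatter, at least on this one pair. Nothing available here explains why these two groups read alike.

This pair cannot say whether the result extends to other groups at this position, such as cyclohexyl, a saturated ring of carbon, or to groups carrying an amine or a carboxylic acid. Going by these compounds, the hydroxy group on this carbon is also present in all three compounds, so its own contribution remains open, as does the outcome of the same swap on a different core.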